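Swapping a Propenyl Chain for a Furan Ring

The source may report more compounds than this note shows. Statements on the series, on what has been measured and on what is new or still open speak of the compounds shown alone.

Compound 3 `C/C=C/CN(C1=NCCN1)c1c(Br)cccc1Br` gives -0.49 in a physicochemical assay for lipophilicity; a lower number here means a more polar compound, a higher number a more lipophilic compound. Among the three numbers available, this value is the second highest. Its nearest neighbour is compound 1 `Brc1ccc(Br)c(N(CC2CC2)C2=NCCN2)c1`, which gives -0.52 in this assay, a value within the usual scatter of compound 3. The furthest is compound 2 `Brc1cccc(N(CC2CC2)C2=NCCN2)c1Br`, which gives -0.41, again within the scatter. The three measured compounds therefore cannot be told apart on this assay; all of them sit in the polar range.

Compound 4 `Brc1cccc(Br)c1N(Cc1ccco1)C1=NCCN1` has not yet been measured. It differs from compound 3 in one place: furan-2-yl in place of prop-1-en-1-yl on a saturated chain carbon bound to a nitrogen on an aromatic ring Cut one bond further out, the change reads but-2-en-1-yl to (furan-2-yl)methyl.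

Among the compounds with values here, no step between measured compounds informs this change, so the expectation rests on the three values alone. The author expects a step of a number 0.09 log units higher from compound 3 to compound 4 (within the scatter), which should not exceed the scatter. Compound 4 is therefore estimated at -0.4, with a range from -0.9 to 0.1.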

Compound 4, distribution coefficient: -0.52
Compound 4: middle estimate off by 0.12 log units, on the high side; the range from low to high includes it.
By their numbers in this assay, from the lowest: compounds 1, 4, 3 and 2 (each within the scatter of the next).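

In this assay, putting furan-2-yl in place of prop-1-en-1-yl on a saturated chain carbon bound to a nitrogen on an aromatic ring gives a step of a number 0.03 log units lower from compound 3 to compound 4 (within the scatter). Within the data shown here, this is the first step read at this position, and it shows that a five-membered aromatic ring with 1 hetero atom and 1 hydrogen-bond acceptor can enter here without separating the two compounds on this read-out. Nothing available explains the size of this step.

Going by these compounds, whether an amine or a carboxylic acid at this place would move the number beyond the scatter remains open, as does the effect of a longer chain. The compounds shown also leave open whether this exchange would give a similar step in any read-out other than this assay.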